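The source may report more compounds than this note shows. Statements on the series, on what has been measured and on what is new or still open speak of the compounds shown alone.

In a functional assay on K562 cells (Homo sapiens) for inhibition, read by trypan blue exclusion, with a stated time of 48 h (on this read-out higher numbers stand for weaker inhibition and lower numbers for stronger inhibition), compound 2 `NC(=O)c1cc(Br)ccc1NC(=O)/C=C/c1ccccc1Cl` gives 8100 nM. Compound 3 `NC(=O)c1cc(Br)ccc1NC(=O)/C=C/c1ccc(Cl)cc1` reaches only a limit, > 10000 nM. Compound 1 `NC(=O)c1cc(Cl)ccc1NC(=O)/C=C/c1cccc(Br)c1` likewise gives only a limit, > 10000 nM. Going by the values given here, the one measured step, an at least 1.2-fold higher number from compound 2 to compound 3 (0.09 log units; that floor lies within the scatter), stays within the scatter, and one end of it is a limit. Compound 4 `NC(=O)c1cc(Br)ccc1NC(=O)/C=C/c1cccc(Br)c1` keeps the core of compound 3 and carries this change: 3-bromophenyl in place of 4-chlorophenyl on a double-bonded chain carbon bound to a double-bonded chain carbon. Among the compounds with values here, no measured step shows this exchange directly. Compound 1 bears the same 3-bromophenyl, and its > 10000 nM is again a limit. No change beyond the scatter is therefore expected in this assay, and the expected step is a step that the limit leaves unreadable from compound 3 to compound 4. Compound 4 is estimated at 12000 nM, with an expected range of 7000 nM to 25000 nM.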

Compound 4, half-maximal inhibitory concentration: > 10000 nM
Compound 4: no number, only a limit; the forecaster's own chance of this, stated with the estimate: 75%; the middle value does not contradict the limit.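

In this assay compound 4 gives > 10000 nM, which is a limit. Going by these compounds alone, the steps from compound 3 and from compound 1 to compound 4 cannot be read, as both ends of each are limits: the limit of > 10000 nM in this assay, at which 3 of the 4 values shown sit. The only step that can be read is an at least 1.2-fold higher number from compound 2 to compound 4 (0.09 log units; that floor lies within the scatter), and it gives a floor for the exchange of 2-chlorophenyl for 3-bromophenyl, not a size.

As far as these compounds go, how far any of these halogen-bearing phenyl groups lies past the limit stays open. So does how an amine or a carboxylic acid on this phenyl ring would read in this assay.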